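One More Methyl: From Compound 2 to Compound 3

The compounds below may be only part of what the source reports. "The series", "measured", "known", "first", "only" and "open" are said of these compounds alone.

Compound 2 `Cc1ccccc1NS(=O)(=O)c1ccc(N2CCNC2=O)cc1`: 280 nM
Compound 1 `CCCCCc1ccc(NS(=O)(=O)c2ccc(N3CCNC3=O)cc2)cc1`: > 1000 nM

In a functional assay on MCF7 cells (Homo sapiens) for antiproliferative activity, read by sulforhodamine B assay, with a stated time of 48 h (a lower number here means a stronger inhibitor, a higher number a weaker inhibitor), compound 2 gives 280 nM, the only true number among the two results shown. For compound 1 the result of > 1000 nM is a limit of the assay, not a number. Compound 3 `Cc1cccc(NS(=O)(=O)c2ccc(N3CCNC3=O)cc2)c1C` differs from compound 2 in a single place: methyl in place of hydrogen on an aromatic carbon. Within the data shown here, no measured pair shows what such a change does, so the step in this assay is expected to stay within the usual scatter, with no clear direction. Compound 3 is therefore estimated at 300 nM, within a range from 120 nM to 800 nM, a step of a 1.1-fold higher number from compound 2 to compound 3 (0.03 log units; within the scatter).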

Compound 3, half-maximal inhibitory concentration: 230 nM
For compound 3 the middle estimate is 1.3-fold (0.12 log units) above the measured one; low and high end bracket the measured number.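

In this assay the change from 2-methylphenyl to 2,3-dimethylphenyl gives a 1.2-fold lower number from compound 2 to compound 3 (0.09 log units; within the scatter), so a methyl at this position, ortho to a methyl group, brings no clear shift in the number. Among these compounds, the earlier compounds offered no measured pair for this change, and this is the only reading of it so far. Nothing measured here gives a reason for this result.

One methyl at one position leaves open what an amine or a carboxylic acid would do there. A single pair also cannot show whether a methyl would act alike elsewhere on this ring.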